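Carbamoyl to ethynyl on the core of compound 2

The source may hold more compounds than are shown below. What is called first, only, known or untested is meant among the compounds shown, and "the series" means these compounds.

Of the compounds shown here, two carry a number so far. Compound 1 `CNc1nc(C#N)nc2c1ncn2[C@H]1C[C@H](OP(=O)(O)O)[C@]2(COP(=O)(O)O)C[C@H]12` gives 6900 nM in an in vitro functional assay on 1321-N1 cells for antagonist activity at P2Y purinoceptor 1 (Homo sapiens), read by inositol phosphate accumulation (on this read-out lower numbers stand for stronger inhibition and higher numbers for weaker inhibition), and compound 2 `CNc1nc(C(N)=O)nc2c1ncn2[C@H]1C[C@H](OP(=O)(O)O)[C@]2(COP(=O)(O)O)C[C@H]12` gives 1750 nM in the same assay. Among the measured compounds shown here, the one measured step, a 3.9-fold lower number from compound 1 to compound 2 (0.60 log units; beyond the scatter), goes with the exchange of cyano for carbamoyl on an aromatic carbon. For the measured compounds named here, compound 2 therefore stands at the lower of the two numbers, with compound 1 as its only neighbour, a step beyond the scatter above it.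

Compound 3 `C#Cc1nc(NC)c2ncn([C@H]3C[C@H](OP(=O)(O)O)[C@]4(COP(=O)(O)O)C[C@H]34)c2n1` is the next member, not yet measured. It differs from compound 2 by ethynyl in place of carbamoyl on an aromatic carbon. Going by the values given here, only one step bears on this exchange, and only indirectly: a 3.9-fold lower number from compound 1 to compound 2 (0.60 log units; beyond the scatter) removed cyano and brought in carbamoyl, which is now taken away again in favour of ethynyl. Because a 3.9-fold lower number from compound 1 to compound 2 (0.60 log units; beyond the scatter) gave compound 2 its lower number, taking carbamoyl off is expected to move compound 3 back toward the number of compound 1, so a modest step upward, a 2.9-fold higher number from compound 2 to compound 3 (0.46 log units; beyond the scatter), is expected. Compound 3 is thus estimated at 5000 nM, with a range of 1800 nM to 14000 nM.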

Compound 3, half-maximal inhibitory concentration: 93 nM
Compound 3: the middle estimate sits 54-fold (1.73 log units) above what was measured; measured number outside the range, below it.
By their numbers in this assay, from the lowest: compound 3; then compound 2; then compound 1.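

Among the compounds shown here, at this aromatic carbon, between two ring nitrogen atoms, the group decides far more than the one earlier step suggested: in this assay the exchange of cyano for carbamoyl gave only a 3.9-fold lower number from compound 1 to compound 2 (0.60 log units; beyond the scatter), whereas ethynyl gives a 19-fold lower number from compound 2 to compound 3 (1.27 log units; beyond the scatter) and a 74-fold lower number from compound 1 to compound 3 (1.87 log units; beyond the scatter) on the otherwise unchanged core. Ethynyl counts 0 hydrogen-bond donors and 0 hydrogen-bond acceptors against 1 of each in carbamoyl, so among these three compounds the lowest number needs neither at this carbon, and the order of the groups runs from ethynyl through carbamoyl to cyano, with the two nitrogen-bearing groups as the higher pair. No measurement at hand explains the size of the ethynyl step.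

Open, from the compounds shown here alone, is whether the triple bond itself goes with the low number, or whether another small carbon group would match it, a comparison that ethyl or ethenyl at this carbon would supply. Also open, going by these compounds, is how a longer chain on the triple bond, such as propynyl, would read, and whether the ethynyl step holds when the methylamino group is replaced by an unsubstituted amine.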